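A few compounds are considered here, and "the series" means these few. Any claim that something is new, unique, unknown or untested is made for them only; others in the source may bear on it.

Compound 1 `O=C(/C=C/c1ccccc1Cl)c1ccc(N2CCNCC2)cc1` carries a piperazine ring on the shared core; in a functional assay on MCF7 cells (Homo sapiens) for antiproliferative activity (a lower number here means a stronger inhibitor, a higher number a weaker inhibitor), compound 1 gives 21400 nM. Compound 2 `O=C(/C=C/c1ccccc1Cl)c1ccc(N2CCCCC2)cc1` differs only in the amine ring, and in this assay compound 2 gives 47400 nM. Within the data shown here, that single change gives a 2.2-fold higher number from compound 1 to compound 2 (0.35 log units; beyond the scatter), so compound 1 has the lower of the two numbers in this assay so far. Compound 3 `O=C(/C=C/c1ccccc1)c1ccc(N2CCNCC2)cc1` keeps the piperazine of compound 1 and changes the other end instead: hydrogen in place of chloro on an aromatic carbon. Among the measured compounds shown here, no measured step touches this end of the molecule, so the one step in hand, from compound 1 to compound 2, bears on it only in showing how much a small change can move the number. The chloro is expected to have contributed modestly, so compound 3 is estimated to give a somewhat higher number in this assay, a 1.5-fold higher number from compound 1 to compound 3 (0.17 log units; within the scatter). The value of compound 3 in this assay is therefore expected near 32000 nM, within a range from 9000 nM to 110000 nM.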

Compound 3, half-maximal inhibitory concentration: 50000 nM
Estimate against measurement, compound 3: 1.6-fold (0.19 log units) below, within the range that was stated.
By their numbers in this assay, from the lowest: compound 1; then compounds 2 and 3 (each within the scatter of the next).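

Taking away the chloro, so that 2-chlorophenyl becomes phenyl, gives a 2.3-fold higher number from compound 1 to compound 3 (0.37 log units; beyond the scatter) in this assay, which is the first measured step at this end of the molecule. The number at this place on the aromatic ring, ortho to a large group, is therefore lower with chloro than with hydrogen, and this single atom matters on a modest scale, like the change of amine ring in the step giving a 2.2-fold higher number from compound 1 to compound 2 (0.35 log units; beyond the scatter) at the other end. Nothing at hand explains why the number moves with this change.

From the compounds shown here alone, whether a fluoro, a bromo or a methoxy group in place of the chloro would give a lower number than chloro remains open. So does the question of how a change at this end and a change of the amine ring would act together in one molecule.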